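Aryl exchange on the shared core: compound 3 to compound 4

The source may report more compounds than this note shows. Statements on the series, on what has been measured and on what is new or still open speak of the compounds shown alone.

In a functional assay on KB cells (Homo sapiens) for antiproliferative activity, read by sulforhodamine B assay, with a stated time of 3 days (on this read-out lower numbers stand for an effect already at smaller amounts and higher numbers for an effect only at larger amounts of compound), compound 3 `CCC1=C(O)c2c(oc(-c3ccc(C)c(F)c3)cc2=O)C(CC)(CC)C1=O` gives 28.1 uM and compound 2 `CCC1=C(O)c2c(oc(-c3cccc(C)c3)cc2=O)C(CC)(CC)C1=O` gives 49.7 uM in the same read-out. The step between them is a 1.8-fold lower number from compound 2 to compound 3 (0.25 log units; within the scatter) and sets no order, so compound 3 stands with compound 2 and no number shown lies clearly apart from it. Compound 1 `CCC1=C(O)c2c(oc(-c3ccc(COC)cc3)cc2=O)C(CC)(CC)C1=O` reads > 52.4 uM as a limit, not a number. The steps from that limit are an at least 1.0-fold lower number from compound 1 to compound 2 (0.02 log units; that floor lies within the scatter) and an at least 1.8-fold lower number from compound 1 to compound 3 (0.27 log units; that floor lies within the scatter) as floors only.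

Compound 4 `CCC1=C(O)c2c(oc(-c3ccc(OC)c(Cl)c3)cc2=O)C(CC)(CC)C1=O` is still unmeasured. Its difference is 3-chloro-4-methoxyphenyl in place of 3-fluoro-4-methylphenyl on an aromatic carbon and puts 3-chloro-4-methoxyphenyl in place of 3-fluoro-4-methylphenyl on the aromatic carbon next to the ring oxygen. Within the data shown here, no measured step makes this exact exchange. The closest evidence is the aryl exchange between compound 2 and compound 3, given as a 1.8-fold lower number from compound 2 to compound 3 (0.25 log units; within the scatter) and bearing on the expectation here. No change beyond the scatter is therefore expected in this assay, in either direction. The expected step is a 1.1-fold higher number from compound 3 to compound 4 (0.03 log units; within the scatter) and remains an estimate. A reading at a limit also remains possible for compound 4. For compound 4 the estimated value is 30 uM with an expected range from 13 uM to 55 uM in this read-out.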

Compound 4, concentration for half-maximal effect: 24.9 uM
Beside the measured number, compound 4's estimate is 1.2-fold (0.08 log units) above it, within the range that was stated.
By their numbers in this assay, from the lowest: compounds 4, 3 and 2 (each within the scatter of the next). At a limit, above all of these: compound 1.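

In this assay, 3-chloro-4-methoxyphenyl can take the place of 3-fluoro-4-methylphenyl on this aromatic carbon next to the ring oxygen with a 1.1-fold lower number from compound 3 to compound 4 (0.05 log units; within the scatter), although the entering group carries a hydrogen-bond acceptor and the leaving group carries none. The wider exchange from 3-methylphenyl gives a 2.0-fold lower number from compound 2 to compound 4 (0.30 log units; within the scatter), so these three aryl groups remain one set without an order, and neither the chlorine with the methoxy group nor the fluorine with the methyl group separates from the plain 3-methylphenyl group. The first step in the series printed as beyond the scatter is an at least 2.1-fold lower number from compound 1 to compound 4 (0.32 log units; beyond the scatter), which is a floor and not a measured size, since it starts from a limit: the limit of > 52.4 uM in this assay, at which 1 of the 4 values shown sits.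

As far as these compounds go, what an aminomethyl group or a carboxylic acid on this phenyl ring would give in this assay stays open, as does whether any aryl group on this carbon can move the number clearly away from those of compound 2, compound 3 and compound 4. The compounds shown also leave open how a propyl chain in place of the ethyl groups on the shared core would read.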